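This account rests on a few compounds, and the source may have more. Where it says the series, first, only, none or still open, it means among the compounds named here.

In a functional assay on A549 cells (Homo sapiens) for cytotoxicity, read by MTT assay, with a stated time of 48 h (on this read-out higher numbers stand for weaker inhibition and lower numbers for stronger inhibition), the measurements so far are:

compound 1 `COc1c(OCc2cnoc2C)cc(O)c2c(=O)cc(-c3ccccc3)oc12` with > 100000 nM as its entry
compound 2 `CCCCNCCOc1c(O)cc(O)c2c(=O)cc(-c3ccccc3)oc12` with "not determined" (no result reported) as its entry

The entry for compound 1 is a limit of the assay and not a number. Compound 2 has no number at all, so it holds no place on the scale, and the only fixed point is a single limit (the limit of > 100000 nM in this assay, at which 1 of the 2 values shown sits).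

Compound 3 `CN1CCN(CCCOc2c(O)cc(O)c3c(=O)cc(-c4ccccc4)oc23)CC1` has not yet been measured. It differs from compound 2 by one change ((4-methylpiperazin-1-yl)methyl in place of butylamino on a saturated chain carbon, two bonds along the chain from an oxygen on an aromatic ring) in the side chain. Cut one bond further out, the same difference reads 2-(butylamino)ethyl to 3-(4-methylpiperazin-1-yl)propyl.

Without a starting number for compound 2, the step in this assay cannot be given a size from measured data. The expectation is therefore only a loose one: weak inhibition, moderately on the stronger side of the limit seen for compound 1, with a real chance that compound 3 also reaches that limit. Compound 3 is expected at 35000 nM as the estimate, with 7000 nM to 100000 nM as its estimated range.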

Compound 3, half-maximal inhibitory concentration: > 100000 nM
Compound 3 ended at the assay's limit (the forecaster's own chance of this, stated with the estimate: 35%); middle value at least 2.8-fold (0.45 log units) away from the limit.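

Compound 3 gives > 100000 nM, which is a limit of the assay and not a number. Compound 2 has no number, so no step can be read between compound 2 and compound 3. The compounds shown leave open whether changing the side chain alters cytotoxicity at all, as the only fixed point is a limit: the limit of > 100000 nM in this assay, at which 2 of the 3 values shown sit.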